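The source may report more compounds than this note shows. Statements on the series, on what has been measured and on what is new or still open speak of the compounds shown alone.

Within the data shown here, compound 1 `O=C1O[C@H]([C@@H](O)Cn2cc(-c3cccc(O)c3)nn2)C(OCc2ccccc2)=C1OCc1ccccc1` is the only compound of this set with a number in an ADME assay on HFF cells (Homo sapiens) for cytotoxicity, read by MTT assay, with a stated time of 72 h; on this read-out lower numbers stand for stronger inhibition and higher numbers for weaker inhibition: in this assay compound 1 gives 39000 nM. Compound 2 `CCCCCc1ccc(-c2cn(C/C=C3\OC(=O)C(OCc4ccccc4)=C3OCc3ccccc3)nn2)cc1` returns only a limit of the assay, > 100000 nM, and not a number; this is the limit of > 100000 nM in this assay, at which 1 of the 2 values shown sits. Compound 3 `O=C1O[C@H]([C@@H](O)Cn2cc(CCCCl)nn2)C(OCc2ccccc2)=C1OCc1ccccc1` has not yet been measured in this assay. It differs from compound 1 in one place: 3-chloropropyl in place of 3-hydroxyphenyl on an aromatic carbon. Among the measured compounds shown here, no step between measured compounds is available, so no size is known; a shift staying within the scatter, in either direction, is expected. Compound 3 is estimated at 40000 nM, with a range from 15000 nM to 100000 nM. This estimate means an expected step of a 1.0-fold higher number from compound 1 to compound 3 (0.01 log units; within the scatter).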

Compound 3, half-maximal inhibitory concentration: 27100 nM
Compound 3: middle estimate off by 1.5-fold (0.17 log units), on the high side, and the stated range covers the measured number.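

In this assay, putting 3-chloropropyl in place of 3-hydroxyphenyl on this aromatic carbon gives a 1.4-fold lower number from compound 1 to compound 3 (0.16 log units; within the scatter). Among these compounds, the first direct comparison at this position thus shows that a chain with no ring, no hydrogen-bond donor and no hydrogen-bond acceptor can stand in for the hydroxylated aromatic ring with the read-out staying within the scatter. Nothing measured here accounts for this step. As far as these compounds go, whether an amine, a carboxylic acid or a longer chain at this position would also stay within the scatter of compound 1 remains open.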